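Replacing pyrrolidin-1-yl with benzylamino in compound 3

The compounds below may be only part of what the source reports. "The series", "measured", "known", "first", "only" and "open" are said of these compounds alone.

In a functional assay on U-937 cells (Homo sapiens) for antiproliferative activity, read by MTT assay, with a stated time of 24 h (a higher number here means a weaker inhibitor, a lower number a stronger inhibitor), three compounds built on a shared core have been measured. Compound 1 (`CCCCc1oc2ccccc2c1C(=O)c1ccc(OCC(=O)N2CCCC2)cc1`) gives 32500 nM, compound 2 (`CCCCc1oc2ccccc2c1C(=O)c1ccc(OCC(=O)Nc2ccccc2)cc1`) gives 25900 nM, and compound 3 (`CCCCc1oc2ccccc2c1C(=O)c1ccc(OCCCC(=O)N2CCCC2)cc1`) gives 7500 nM. Compound 3 has the lowest of the three numbers, and it stands apart from both others beyond the scatter, as shown by a 4.3-fold lower number from compound 1 to compound 3 (0.64 log units; beyond the scatter) and a 3.5-fold lower number from compound 2 to compound 3 (0.54 log units; beyond the scatter).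

Compound 4 (`CCCCc1oc2ccccc2c1C(=O)c1ccc(OCCCC(=O)NCc2ccccc2)cc1`) differs from compound 3 in one place, with benzylamino in place of pyrrolidin-1-yl on a carbonyl carbon.

The closest guide is a 1.3-fold lower number from compound 1 to compound 2 (0.10 log units; within the scatter), a step within the scatter, in which anilino took the place of pyrrolidin-1-yl on a carbonyl carbon. It is only an approximate guide, since anilino is not benzylamino and that step was made on a different chain. The two larger steps both alter the group on a saturated chain carbon bound to an oxygen on an aromatic ring, and that chain is the same in compound 3 and compound 4. Among the compounds with values here, no measured pair tests benzylamino directly, so no step beyond the scatter is expected in this assay, though the uncertainty is wide in both directions.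

The expected change is no change at the digits printed from compound 3 to compound 4 (within the scatter). For compound 4 the estimated value is 7500 nM, with an expected range from 3200 nM to 17000 nM.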

Compound 4, half-maximal inhibitory concentration: 15800 nM
Beside the measured number, compound 4's estimate is 2.1-fold (0.32 log units) below it; low and high end bracket the measured number.
By their numbers in this assay, from the lowest: compound 3; then compounds 4, 2 and 1 (each within the scatter of the next, the first and the last beyond it).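

In this assay, the carbonyl carbon carrying pyrrolidin-1-yl in compound 3 proves to be a place where the amine part of the amide counts, since benzylamino brings a modest loss (a 2.1-fold higher number from compound 3 to compound 4 (0.32 log units; beyond the scatter)) that lies beyond the scatter. The earlier swap at a carbonyl carbon, anilino for pyrrolidin-1-yl on the chain of compound 1 (a 1.3-fold lower number from compound 1 to compound 2 (0.10 log units; within the scatter)), stayed within the scatter, so the two amine swaps do not read alike, though they differ in both the entering group and the chain that carries it. Nothing available accounts for the step, which therefore stands as an observation without an explanation.

The change replaces a five-membered non-aromatic ring that has no hydrogen-bond donor with an open benzylamino group that has one, and these compounds cannot separate the ring, the amide hydrogen and the added phenyl ring as the source of the difference. Anilino on the chain of compound 3, or a tertiary amide such as piperidin-1-yl or N-methylbenzylamino at the same carbonyl carbon, would bear on that question, and it also remains open whether a still longer chain would carry either amine differently.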